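The compounds below may be only part of what the source reports. "The series", "measured", "known", "first", "only" and "open" are said of these compounds alone.

Series notes. Compound 1 `Cn1c(Cc2nn(C)c(=O)c3ccccc23)ccc1SCC(=O)c1ccc(Cl)cc1Cl` gives 69000 nM in an assay on isolated protein for inhibition of thyroid hormone receptor alpha (Homo sapiens); a higher number here means a weaker inhibitor, a lower number a stronger inhibitor. Compound 2 `N=C(CCl)N(N)S(=O)(=O)c1cc(Cl)c(Oc2ccc([N+](=O)[O-])cc2Cl)c(Cl)c1` gives 1800 nM in this assay, and compound 3 `N=C(c1ccccn1)N(N)S(=O)(=O)c1cc(Cl)c(Oc2ccc([N+](=O)[O-])cc2Cl)c(Cl)c1` gives 39000 nM in this assay. Among these three numbers compound 3 stands second highest; its nearest neighbour is compound 1, which lies within the scatter of it, and its furthest is compound 2, which lies beyond the scatter. Among the measured compounds shown here, the single one-point step recorded is a 22-fold higher number from compound 2 to compound 3 (1.34 log units; beyond the scatter).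

Compound 4 `N=C(c1cc(Cl)cc(Cl)c1)N(N)S(=O)(=O)c1cc(Cl)c(Oc2ccc([N+](=O)[O-])cc2Cl)c(Cl)c1` has not yet been measured. Its change from compound 3 is 3,5-dichlorophenyl in place of pyridin-2-yl on a carbon with a double bond to nitrogen. For the measured compounds named here, no recorded step exchanges one aromatic group for another on this carbon; the only step touching this position, a 22-fold higher number from compound 2 to compound 3 (1.34 log units; beyond the scatter), runs from chloromethyl to pyridin-2-yl and is therefore of a different kind. It offers no guide to the size or direction of the present change, and nothing else in the series bears on it. In the absence of a comparable step, compound 4 is expected to sit near compound 3. For compound 4 the step of a 1.3-fold lower number from compound 3 to compound 4 (0.11 log units; within the scatter) is expected to remain within the scatter. Compound 4 is accordingly estimated at 30000 nM in this assay, with a range from 8000 nM to 100000 nM.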

Compound 4, half-maximal inhibitory concentration: 930 nM
For compound 4 the middle estimate is 32-fold (1.51 log units) above the measured one; measured number below the stated range.
By their numbers in this assay, from the lowest: compounds 4 and 2 (each within the scatter of the next); then compounds 3 and 1 (each within the scatter of the next).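

In this assay, exchanging one aromatic group for another on the carbon with a double bond to nitrogen gives a 42-fold lower number from compound 3 to compound 4 (1.62 log units; beyond the scatter), so the earlier rise with pyridin-2-yl does not extend to every aromatic group at this place. Among the compounds shown here, the exchange of chloromethyl for 3,5-dichlorophenyl gives a 1.9-fold lower number from compound 2 to compound 4 (0.29 log units; within the scatter), which leaves these two groups without an order and makes pyridin-2-yl the only one of the three groups that stands apart. This position therefore tolerates both a small chloromethyl group and a ring carrying two chlorines with no difference beyond the scatter, while the identity of the ring decides the outcome, and no measurement available bears on the reason for the gap between the two rings.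

The compounds shown leave open whether the high number of compound 3 goes with the ring nitrogen of pyridin-2-yl or with the absence of the two chlorines, a question that unsubstituted phenyl on this carbon would separate. Going by these compounds, how a single chlorine on the phenyl ring, a longer chain or an amine would read at this place also remains open.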